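The source may hold more compounds than are shown below. What is called first, only, known or untested is meant among the compounds shown, and "the series" means these compounds.

Compound 1 `CCn1c(C(=O)N[C@@H](C)CO)ccc1C(CC)(CC)c1ccc(OCS(=O)(=O)c2ccccc2)c(C)c1` is one of three compounds built on a shared core, joined in a functional assay on BXPC-3 cells (Homo sapiens) for antiproliferative activity, read by MTT assay, with a stated time of 24 h (a higher number here means a weaker inhibitor, a lower number a stronger inhibitor), by compound 2 `CCn1c(C(=O)N[C@H](C)C(=O)O)ccc1C(CC)(CC)c1ccc(OCS(=O)(=O)c2ccccc2)c(C)c1` and compound 3 `CCn1c(C(=O)N[C@H](C(=O)O)C(C)C)ccc1C(CC)(CC)c1ccc(OCS(=O)(=O)c2ccccc2)c(C)c1`. In this assay compound 1 gives 15300 nM, compound 2 gives 20100 nM and compound 3 gives 16200 nM. Compound 1 holds the lowest of the three numbers, but every step among them stays within the scatter: a 1.3-fold higher number from compound 1 to compound 2 (0.12 log units; within the scatter), a 1.1-fold higher number from compound 1 to compound 3 (0.02 log units; within the scatter) and a 1.2-fold lower number from compound 2 to compound 3 (0.09 log units; within the scatter).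

Compound 4 `CCn1c(C(=O)N[C@@H](C(=O)O)C(C)C)ccc1C(CC)(CC)c1ccc(OCS(=O)(=O)c2ccccc2)c(C)c1` has not yet been measured. It differs from compound 1 as follows: 1-carboxy-2-methylpropyl in place of 1-(hydroxymethyl)ethyl on an amide-type nitrogen. Compound 3 carries the same group on the amide-type nitrogen, and the step of a 1.1-fold higher number from compound 1 to compound 3 (0.02 log units; within the scatter) is the one that bears most directly on this change; the step of a 1.3-fold higher number from compound 1 to compound 2 (0.12 log units; within the scatter) points the same way. Since neither of these steps moved beyond the scatter, no change beyond the scatter is expected for compound 4 in this assay. For compound 4 the estimated value is therefore 16500 nM, within a range of 9000 nM to 30000 nM, which means an expected step of a 1.1-fold higher number from compound 1 to compound 4 (0.03 log units; within the scatter).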

Compound 4, half-maximal inhibitory concentration: 13900 nM
Beside the measured number, compound 4's estimate is 1.2-fold (0.07 log units) above it; low and high end bracket the measured number.
By their numbers in this assay, from the lowest: compounds 4, 1, 3 and 2 (each within the scatter of the next).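

In this assay, the configuration drawn at the saturated chain carbon bound to the amide-type nitrogen can now be read on its own, giving a 1.2-fold lower number from compound 3 to compound 4 (0.07 log units; within the scatter), and the pair is a clean test of that single stereocentre: the fact that compounds 3 and 4 differ only in the configuration as drawn. The change from 1-(hydroxymethyl)ethyl to 1-carboxy-2-methylpropyl now also has a second reading with the other drawn configuration, a 1.1-fold lower number from compound 1 to compound 4 (0.04 log units; within the scatter), while isopropyl in place of methyl on that carbon gives a 1.4-fold lower number from compound 2 to compound 4 (0.16 log units; within the scatter). All of these steps stay within the scatter, so among these compounds neither the configuration nor the isopropyl group moves the number beyond it.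

Going by these compounds, whether an amine, a primary amide or a benzyl group at this place would do so remains open. Also open, on these data alone, is whether configuration counts in the same way with the 1-carboxyethyl group.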